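From Methyl to a Large Ring Group on Nitrogen

The source may report more compounds than this note shows. Statements on the series, on what has been measured and on what is new or still open speak of the compounds shown alone.

Within the data shown here, in a functional assay on LNCaP cells (Homo sapiens) for cytotoxicity (a higher number here means a weaker inhibitor, a lower number a stronger inhibitor), compound 1 `CNC(=O)Nc1ccc(-c2nc(N3CC4CCC(C3)O4)c3cnn(C)c3n2)cc1` gives 170 nM, the highest of the three numbers measured so far. Compound 2 `O=C(Nc1ccc(-c2nc(N3CC4CCC(C3)O4)c3cnn(C4CCC5(CC4)OCCO5)c3n2)cc1)Nc1cccnc1` gives 1 nM and compound 3 `O=C(Nc1ccncc1)Nc1ccc(-c2nc(N3CC4CCC(C3)O4)c3cnn(C4CCC5(CC4)OCCO5)c3n2)cc1` gives 1 nM, both well beyond the scatter from compound 1.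

The unmeasured compound 4 `CNC(=O)Nc1ccc(-c2nc(N3CC4CCC(C3)O4)c3cnn(C4CCC5(CC4)OCCCO5)c3n2)cc1` keeps the rest of compound 1 and differs from it at one place: a group of 11 heavy atoms (9 carbon, 2 oxygen; one six-membered non-aromatic ring of carbon only, one six-membered non-aromatic ring with 2 hetero atoms) in place of one carbon atom, on an aromatic nitrogen. Compound 2 and compound 3 also carry a large group with two ring systems on that aromatic nitrogen, but they have a pyridinyl group where compound 1 has a methyl on an amide-type nitrogen. Their gap from compound 1 therefore cannot be assigned to the group on the aromatic nitrogen alone.

Among the measured compounds shown here, the only measured step, no change at the digits printed from compound 2 to compound 3 (within the scatter), concerns the pyridinyl group and says nothing directly about the change at the aromatic nitrogen. It does suggest that the position of the pyridine nitrogen matters little in this series, though that rests on one pair.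

A substantial fall is expected in this assay, though probably not the whole gap, and the estimated step is a 17-fold lower number from compound 1 to compound 4 (1.23 log units; beyond the scatter). For compound 4 the expected value is 10 nM, with an estimated range of 2 nM to 50 nM.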

Compound 4, half-maximal inhibitory concentration: 8 nM
The estimate for compound 4 lay 1.3-fold (0.10 log units) above the measured number; measured number inside the range.
By their numbers in this assay, from the lowest: compounds 2 and 3 (each within the scatter of the next); then compound 4; then compound 1.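

The pair of compound 1 and compound 4 isolates the group on the aromatic nitrogen, with the methyl on the amide-type nitrogen held in place, and this assay records a 21-fold lower number from compound 1 to compound 4 (1.33 log units; beyond the scatter). This shows that the change at this position moves the number by a large step on its own, without any pyridinyl group on the amide-type nitrogen, whereas the gaps from compound 1 to compound 2 and compound 3 each combined two changes. Nothing measured here accounts for the size of this step.

The compounds shown leave open which part of the entering group carries the step, and a plain cyclohexyl group or a cyclohexanone on the aromatic nitrogen, or a simple ethyl group there, would begin to separate the carbon-only ring from the ring with two oxygens. Among these compounds, they also leave open how the two sites work together, since no pair here changes the amide-type nitrogen while the group of compound 4 stays on the aromatic nitrogen.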